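An Amino Group Enters the Core of Compound 3

The source may report more compounds than this note shows. Statements on the series, on what has been measured and on what is new or still open speak of the compounds shown alone.

Compound 1, `Nc1nc(N)c2c(-c3ccoc3)cn([C@@H]3O[C@H](CO)[C@@H](O)[C@H]3O)c2n1`, is reported in a functional assay on HCT-116 cells (Homo sapiens), read by MTT assay, with a stated time of 72 h (on this read-out lower numbers stand for stronger inhibition and higher numbers for weaker inhibition), as > 20000 nM, a limit of the assay.
Compound 2, `COc1nc(N)nc2c1c(-c1ccccc1)cn2[C@@H]1O[C@H](CO)[C@@H](O)[C@H]1O`, is reported as > 20000 nM, also a limit.
Compound 3, `COc1ncnc2c1c(-c1ccoc1)cn2[C@@H]1O[C@H](CO)[C@@H](O)[C@H]1O`, gives 110 nM.

For the measured compounds named here, compound 3 thus holds the only number among the three, set against (the limit of > 20000 nM in this assay, at which 2 of the 3 values shown sit). No pair of measured compounds differs in a single place, so no measured step is shown. Compound 4, `COc1nc(N)nc2c1c(-c1ccoc1)cn2[C@@H]1O[C@H](CO)[C@@H](O)[C@H]1O`, differs from compound 3 by amino in place of hydrogen on an aromatic carbon. Compound 2 and compound 1 both carry an amino on the same carbon and both sit at the limit. The step is expected to be a 45-fold higher number from compound 3 to compound 4 (1.66 log units; beyond the scatter), toward weaker inhibition and beyond the usual scatter. Compound 4 is therefore estimated at 5000 nM, with a range of 500 nM to 30000 nM.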

Compound 4, half-maximal inhibitory concentration: > 20000 nM
Compound 4: no number, only a limit; the forecaster's own chance of this, stated with the estimate: 35%; middle value at least 4.0-fold (0.60 log units) away from the limit.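

For the compounds shown here, the amino group on this aromatic carbon, between two ring nitrogen atoms, gives the first readable step: in this assay the change brings an at least 180-fold higher number from compound 3 to compound 4 (2.25 log units; beyond the scatter). On these data alone, compound 4 reports only a limit, not a number, so the step's full size stays unknown, and the compound joins the others there: the limit of > 20000 nM in this assay, at which 3 of the 4 values shown sit. The steps to compound 4 from compound 1 and compound 2 cannot be read, since both ends are limits.

The compounds shown leave open whether a methyl group or a chlorine atom on this carbon would also reach the limit, or whether the loss is particular to amino.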